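From Sulfone to Sulfonamide on a Shared Core

The compounds below may be only part of what the source reports. "The series", "measured", "known", "first", "only" and "open" are said of these compounds alone.

Of the compounds shown here, three built on one shared core have been tested in a functional assay (Cavia porcellus) with sulfonylurea receptors; K-ATP channels (Homo sapiens) as the target; a lower number here means a stronger inhibitor, a higher number a weaker inhibitor. Compound 1 `CC(O)(C(=O)Nc1ccc(S(=O)(=O)c2ccccc2F)cc1)C(F)(F)F` gives 1300 nM in this assay, the lowest of the two numbers reported. Compound 3 `CC(O)(C(=O)Nc1ccc(S(=O)(=O)c2ccccc2)cc1[N+](=O)[O-])C(F)(F)F` gives 7900 nM, a gap from compound 1 that lies beyond the usual scatter. For compound 2 `CC(O)(C(=O)Nc1ccc(S(=O)(=O)c2ccccc2)c(C(F)(F)F)c1)C(F)(F)F` the assay reports only a limit, > 30000 nM, and not a number (the limit of > 30000 nM in this assay, at which 1 of the 3 values shown sits).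

Compound 4 `CN(c1ccccc1)S(=O)(=O)c1ccc(NC(=O)C(C)(O)C(F)(F)F)cc1` has not yet been measured. It differs from compound 1 in a single place: methyl(phenyl)amino in place of 2-fluorophenyl on a sulfonyl sulfur. Going by the values given here, no step between two measured compounds that differ in one place is available to calibrate this change, so its size is open. The expectation is a modest weakening, of a size close to or only slightly beyond the scatter, rather than a large jump. Compound 4 is therefore expected to give about 2500 nM in this assay, with a likely range of 600 nM to 12000 nM. That estimate corresponds to an expected step of a 1.9-fold higher number from compound 1 to compound 4 (0.28 log units; within the scatter).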

Compound 4, half-maximal inhibitory concentration: 2000 nM
Compound 4: middle estimate off by 1.3-fold (0.10 log units), on the high side, within the range that was stated.
By their numbers in this assay, from the lowest: compounds 1 and 4 (each within the scatter of the next); then compound 3. At a limit, above all of these: compound 2.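

In this assay, putting methyl(phenyl)amino in place of 2-fluorophenyl on a sulfonyl sulfur gives a 1.5-fold higher number from compound 1 to compound 4 (0.19 log units; within the scatter), so the two compounds cannot be told apart by this measurement. Going by these compounds alone, this is the first one-place step available on the shared core, and it shows that the group on the sulfonyl sulfur can be joined through nitrogen rather than through an aromatic carbon with no change beyond the scatter. Both groups carry one six-membered aromatic ring of carbon only, so this single pair speaks only to exchanges that keep such a ring.

On these data alone, whether a group without that ring, such as dimethylamino or a carboxylic acid, would be accepted at this place stays open. Nothing measured here bears on why this exchange leaves the number within the scatter.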